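The compounds below may be only part of what the source reports. "The series", "measured", "known", "first", "only" and "open" are said of these compounds alone.

Measured compounds:
Compound 1 `OC[C@H]1O[C@@H](n2cnc3c(NCc4ccc(Br)cc4)ncnc32)[C@H](O)[C@@H]1O` gives in a functional assay on G-361 cells (Homo sapiens) for antiproliferative activity, with a stated time of 72 h (a higher number here means a weaker inhibitor, a lower number a stronger inhibitor), a value of > 166000 nM, which is a limit of the assay rather than a number.
Compound 2 `COc1cccc(CNc2ncnc3c2ncn3[C@@H]2O[C@H](CO)[C@@H](O)[C@H]2O)c1OC` has in this assay the entry "not determined" (no result reported).

Compound 2 thus stands nowhere on the numbers shown: it carries no value of its own, and the only result given for any compound is the limit for compound 1 (the limit of > 166000 nM in this assay, at which 1 of the 2 values shown sits). Compound 3 `OC[C@H]1O[C@@H](n2cnc3c(NCc4ccc(C(F)(F)F)cc4)ncnc32)[C@H](O)[C@@H]1O` differs from compound 2 by 4-(trifluoromethyl)phenyl in place of 2,3-dimethoxyphenyl on a saturated chain carbon bound to a nitrogen on an aromatic ring. Within the data shown here, no step between measured compounds exists, so no size or direction of step in this assay can be drawn from the data. Compound 3 is expected to give about 150000 nM, within 40000 nM to 500000 nM, with a real chance that only a limit is reported.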

Compound 3, half-maximal inhibitory concentration: > 166000 nM
Compound 3: no number, only a limit; the forecaster's own chance of this, stated with the estimate: 70%; middle value at least 1.1-fold (0.04 log units) from the limit.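

No new step can be read between compound 1 and compound 3, since each result in this assay is a limit and not a number: the limit of > 166000 nM in this assay, at which 2 of the 3 values shown sit.

The compounds shown leave open how compound 1 and compound 3 actually compare, and whether any group in this place gives a readable value in this assay.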